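The source may report more compounds than this note shows. Statements on the series, on what has been measured and on what is new or still open speak of the compounds shown alone.

Measured in a physicochemical assay for metabolic stability, read by LC-MS, in simulated gastric fluid, with a stated time of 15 min, tested at 50 uM; on this read-out lower numbers stand for a less stable compound and higher numbers for a more stable compound:
- compound 1 `COc1ccc(CNC(=O)c2c(C)nc3cc(C)ccn23)cc1`: 100%
- compound 2 `O=C(Oc1c(Cl)cc(Cl)cc1Cl)c1coc(-c2ccccc2)n1`: 1.3%
- compound 3 `CCC(C)c1ccccc1OC(=O)c1coc(-c2ccccc2)n1`: 0.2%

Compound 3 stands within the scatter of compound 2 and far beneath compound 1 in this assay. Compound 4 `CC(C)(C)c1ccccc1OC(=O)c1coc(-c2ccccc2)n1` differs from compound 3 in one place: tert-butyl in place of sec-butyl on an aromatic carbon. This puts tert-butyl in place of sec-butyl on an aromatic carbon, ortho to a large group. Going by the values given here, no measured pair isolates this change, so the expectation is weakly grounded. With compound 3 at 0.2% as the only close reference, no step beyond the scatter is expected in this assay. The expected step is small and upward, a number 1.8 percentage points higher from compound 3 to compound 4 (within the scatter). For compound 4 the estimated value is 2%, with an expected range of 0% to 15%.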

Compound 4, percent of the compound remaining: 0.7%
The estimate for compound 4 lay 1.3 percentage points above the measured number; low and high end bracket the measured number.
By their numbers in this assay, from the lowest: compounds 3, 4 and 2 (each within the scatter of the next); then compound 1.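

In this assay tert-butyl in place of sec-butyl gives a number 0.5 percentage points higher from compound 3 to compound 4 (within the scatter) on this aromatic carbon ortho to a large group. This first single-change step shows that exchanging these two groups moves the number by no more than the scatter, and both compounds remain near the bottom of the scale. No supporting measurement explains this result.

From the compounds shown here alone, whether an amine, a carboxylic acid or a longer chain at this position would give a different number remains open. Going by these compounds, the effect of changes elsewhere on the shared core also remains open.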